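Furan for methoxyphenyl on a bicyclic prostaglandin antagonist core

A few compounds are considered here, and "the series" means these few. Any claim that something is new, unique, unknown or untested is made for them only; others in the source may bear on it.

Of the compounds shown here, two have been measured in a functional assay on cells for antagonist activity at prostaglandin E2 receptor EP1 subtype (Rattus norvegicus), read by fluorescence and calcium flux, with a stated time of 60 s; on this read-out higher numbers stand for weaker inhibition and lower numbers for stronger inhibition. Compound 1 `O=C(O)c1cccc(Cc2c(-c3ccccc3)nn3cc(Br)ccc23)n1` gives 11 nM. Compound 2 `COc1ccc(-c2nn3cc(Cl)ccc3c2Cc2cccc(C(=O)O)n2)cc1` gives 5400 nM, the higher of the two numbers and beyond the scatter from compound 1, so compound 2 is the weaker inhibitor of the pair. Compound 3 `O=C(O)c1cccc(Cc2c(-c3ccoc3)nn3cc(Cl)ccc23)n1` has not yet been measured in this assay. It differs from compound 2 in one place: furan-3-yl in place of 4-methoxyphenyl on an aromatic carbon. Within the data shown here, the two compounds differ also in the halogen on the shared core, so no single measured step separates them. With compound 1 carrying a plain phenyl at that position and giving 11 nM, a group smaller than 4-methoxyphenyl is expected to move the number downward, toward stronger inhibition, by a step beyond the scatter. The expected step is a 27-fold lower number from compound 2 to compound 3 (1.43 log units; beyond the scatter). Compound 3 is therefore estimated at 200 nM, within a range from 30 nM to 1500 nM.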

Compound 3, half-maximal inhibitory concentration: 130 nM
For compound 3 the middle estimate is 1.5-fold (0.19 log units) above the measured one; low and high end bracket the measured number.
By their numbers in this assay, from the lowest: compound 1; then compound 3; then compound 2.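

In this assay, putting furan-3-yl in place of 4-methoxyphenyl gives a 42-fold lower number from compound 2 to compound 3 (1.62 log units; beyond the scatter), with the chlorine on the shared core unchanged. This shows that the aromatic carbon of the five-membered ring with 2 nitrogen is sensitive to the group it carries, a point that compound 1 could not show, as it differs from both other compounds in more than one place. The step goes from 8 heavy atoms to 5 with the hydrogen-bond acceptor count unchanged, but nothing measured here accounts for its size.

The compounds shown do not separate the loss of the methoxy group from the change of ring, and compound 1 differs in its halogen as well. Going by these compounds, how thiophen-3-yl, furan-2-yl or 4-hydroxyphenyl would read at this position remains open.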